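This account rests on a few compounds, and the source may have more. Where it says the series, first, only, none or still open, it means among the compounds named here.

Measured so far:
- compound 1, `CC1(C)CC(NC(=O)NCc2ccccc2)c2cc(Cl)ccc2O1`, 66000 nM
- compound 2, `CC1(C)CC(NC(=O)NCc2ccccc2)c2cc(F)ccc2O1`, 11000 nM

Both were read in a functional assay on U-373MG ATCC cells (Homo sapiens) for inhibition, read by MTT assay, with a stated time of 72 h; a lower number here means a stronger inhibitor, a higher number a weaker inhibitor. Compound 2 gives the lowest of the two numbers; its nearest neighbour is compound 1, and the step of a 6.0-fold lower number from compound 1 to compound 2 (0.78 log units; beyond the scatter) is the only one available, arising from fluoro in place of chloro on an aromatic carbon of the shared core.

Compound 3, `CC1(C)CC(NC(=O)Nc2cccc(Cl)c2)c2cc(F)ccc2O1`, is not yet measured. It differs from compound 2 at the other end of the urea: 3-chlorophenyl in place of benzyl on an amide-type nitrogen. Among the compounds with values here, the single measured step concerns a halogen on the core, not the group carried by the amide-type nitrogen, so nothing measured bears directly on this change; the two values only show that compounds with a benzyl on that nitrogen sit in the weak range.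

Within the data shown here, with no relevant step, the expectation for compound 3 is a number close to that of compound 2, the step of no change at the digits printed from compound 2 to compound 3 (within the scatter) being estimated to fall within the scatter. Compound 3 is therefore estimated at 11000 nM in this assay, with a range of 3000 nM to 40000 nM.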

Compound 3, half-maximal inhibitory concentration: 39000 nM
The estimate for compound 3 lay 3.5-fold (0.55 log units) below the measured number; measured number inside the range.
By their numbers in this assay, from the lowest: compound 2; then compounds 3 and 1 (each within the scatter of the next).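

In this assay the group on the amide-type nitrogen proves to be a second place where the number responds, not only the halogen on the core: 3-chlorophenyl in place of benzyl gives a 3.5-fold higher number from compound 2 to compound 3 (0.55 log units; beyond the scatter), a step beyond the scatter and in the weakening direction. Benzyl and 3-chlorophenyl have the same heavy-atom count and each holds one six-membered aromatic ring of carbon only, so the number moves even though those counts stay the same. Nothing on hand accounts for this step.

Still open, from the compounds shown here alone, is which part of the change carries the step: a plain phenyl or a 3-chlorobenzyl on the amide-type nitrogen would separate the chlorine from the loss of the carbon link that benzyl carries. Also open, going by these compounds, are how that nitrogen responds to a non-aromatic group, such as a longer alkyl chain or a chain ending in an amine, and whether the step seen for fluoro in place of chloro on the core holds when 3-chlorophenyl sits on the nitrogen.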